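A few compounds are considered here, and "the series" means these few. Any claim that something is new, unique, unknown or untested is made for them only; others in the source may bear on it.

Working notes on a pair of measured compounds and one awaiting measurement, all sharing the same core. Compound 1 `COc1ccc(-c2cc(NC(=O)CCC(=O)NCC(=O)NC(C)(C)C)nc(-c3ccc(OC)cc3)n2)cc1` was tested in an assay on HeLa cells for displacement of a labelled ligand from adenosine receptor A3 (Homo sapiens), read by fluorescence polarization, with a stated time of 30 min (a higher number here means a weaker inhibitor, a lower number a stronger inhibitor), and gives 15000 nM. Compound 2 `COc1ccc(-c2cc(NC(=O)COCC(=O)NCC(=O)NC(C)(C)C)nc(-c3ccc(OC)cc3)n2)cc1`, tested in the same way, gives in this assay a value of 11200 nM. The two numbers lie within the usual scatter of one another, so neither compound can be placed ahead of the other: compound 2 simply sits alongside compound 1 at a weak level of inhibition, and nothing in these two values points to a direction for further change.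

Compound 3 `COc1ccc(-c2cc(NC(=O)COCC(=O)NCC(=O)NC3CCCCC3)nc(-c3ccc(OC)cc3)n2)cc1` keeps the core and the chain of compound 2 and differs in one place only: cyclohexyl in place of tert-butyl on an amide-type nitrogen. Going by the values given here, no pair of measured compounds shows the effect of a change of this kind, so there is no precedent. A step beyond the scatter is not expected from this swap. The step expected is a 1.1-fold lower number from compound 2 to compound 3 (0.05 log units; within the scatter), in no firm direction. Compound 3 is therefore estimated at 10000 nM in this assay, with a range from 4000 nM to 30000 nM.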

Compound 3, inhibition constant: 14000 nM
For compound 3 the middle estimate is 1.4-fold (0.15 log units) below the measured one, and the stated range covers the measured number.
By their numbers in this assay, from the lowest: compounds 2, 3 and 1 (each within the scatter of the next).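

Going by these compounds alone, the step of a 1.3-fold higher number from compound 2 to compound 3 (0.10 log units; within the scatter) in this assay is the first reading of a change at this position, the amide-type nitrogen, and it lies within the scatter. Cyclohexyl, with its six-membered non-aromatic ring of carbon only, therefore reads the same as tert-butyl here, and compound 3 at 14000 nM stays at the weak level of the earlier compounds, so this swap gives no direction for further change. Nothing among the available data bears on why the number holds across this swap.

Still open, on these data alone, is whether a group of a different kind on this nitrogen, such as an amine, a carboxylic acid or a phenyl ring, would give a step beyond the scatter, since tert-butyl and cyclohexyl are both carbon-only groups with no hydrogen-bond donors or acceptors. Within the data shown here, the single step at this position also stands on the chain of compound 2, so whether cyclohexyl reads the same on the chain of compound 1, or on a longer chain, remains open.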